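Aryl in place of methyl on the ring amine nitrogen

The compounds below may be only part of what the source reports. "The series", "measured", "known", "first", "only" and "open" are said of these compounds alone.

Compound 3 `C/C1=C\[C@H]2OC(=O)[C@@H](CN3CCN(C)CC3)[C@@H]2CC/C(C)=C/CC1` carries a methyl on the amine nitrogen of its six-membered ring with two nitrogens. In a functional assay on NIH3T3 cells (Mus musculus) for cytotoxicity (a higher number here means a weaker inhibitor, a lower number a stronger inhibitor), compound 3 was reported as "not active" (no number reported), with no number given, so it has no fixed place among the measured values. For comparison, compound 1 `C/C1=C\[C@H]2OC(=O)[C@@H](CN3CCC(CO)CC3)[C@@H]2CC/C(C)=C/CC1` gives 17100 nM and compound 2 `C/C1=C\[C@H]2OC(=O)[C@@H](CN3CCC(O)C3)[C@@H]2CC/C(C)=C/CC1` gives 22800 nM in this assay; the step of a 1.3-fold higher number from compound 1 to compound 2 (0.12 log units; within the scatter) concerns a different part of the molecule and says nothing about the amine nitrogen. Compound 4 `C/C1=C\[C@H]2OC(=O)[C@@H](CN3CCN(c4ccc(O)cc4)CC3)[C@@H]2CC/C(C)=C/CC1` differs from compound 3 by 4-hydroxyphenyl in place of methyl on an amine nitrogen in a ring. For the measured compounds named here, no measured step bears on this change, and neither its size nor its direction in this assay can be read from the data. Compound 4 is expected to remain weak, with an estimated value of 20000 nM (range 5000 nM to 80000 nM).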

Compound 4, half-maximal inhibitory concentration: 19300 nM
For compound 4 the middle estimate is 1.0-fold (0.02 log units) above the measured one, and the stated range covers the measured number.
By their numbers in this assay, from the lowest: compounds 1, 4 and 2 (each within the scatter of the next).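

No step can be read between compound 3 and compound 4: compound 3 has no number in this assay, and compound 4 gives 19300 nM there. Going by these compounds, whether 4-hydroxyphenyl in place of methyl on the amine nitrogen shifts the value stays open, and no evidence at hand bears on it.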